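A ring swap on compound 3

The source may report more compounds than this note shows. Statements on the series, on what has been measured and on what is new or still open speak of the compounds shown alone.

Compound 1 `O=C(/C=C/c1cccc(OCc2ccccc2)c1)c1ccc([N+](=O)[O-])cc1` gives 17500 nM
Compound 2 `COc1cc([C@H]2Oc3cc([C@H]4Oc5ccccc5C(=O)[C@@H]4O)ccc3O[C@@H]2CO)ccc1O` gives 13800 nM
Compound 3 `Cc1ccc(C(=O)/C=C/c2cccc(OCc3ccccc3)c2)cc1` gives 21700 nM

In a functional assay on MCF7 cells (Homo sapiens) for cytotoxicity, read by MTT assay, with a stated time of 68 h (on this read-out lower numbers stand for stronger inhibition and higher numbers for weaker inhibition), compound 3 gives 21700 nM and stands within the scatter of both other compounds, so the three values cannot be ranked. Compound 4 `O=C(/C=C/c1cccc(OCc2ccccc2)c1)c1cccc(Br)c1` differs from it by 3-bromophenyl in place of 4-methylphenyl on a carbonyl carbon with 3-bromophenyl in place of 4-methylphenyl on a carbonyl carbon. Going by the values given here, only one measured step bears on this change: a 1.2-fold higher number from compound 1 to compound 3 (0.09 log units; within the scatter) with methyl in place of nitro on an aromatic carbon. That step lies within the scatter. Among the compounds with values here, no measured pair tests a 3-bromophenyl group directly, and compound 2 offers no step at all. A step beyond the scatter is therefore not expected in this assay in either direction. The expected step is a 1.2-fold lower number from compound 3 to compound 4 (0.08 log units; within the scatter) and it stays within the scatter. For compound 4 the estimated value is 18000 nM with 8000 nM to 40000 nM as the expected range.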

Compound 4, half-maximal inhibitory concentration: 7900 nM
For compound 4 the middle estimate is 2.3-fold (0.36 log units) above the measured one, outside the stated range (below it).
By their numbers in this assay, from the lowest: compounds 4, 2, 1 and 3 (each within the scatter of the next, the first and the last beyond it).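

In this assay, the group on the carbonyl carbon can move the number beyond the scatter. The result gives a 2.7-fold lower number from compound 3 to compound 4 (0.44 log units; beyond the scatter) for 3-bromophenyl in place of 4-methylphenyl, and a 2.2-fold lower number from compound 1 to compound 4 (0.35 log units; beyond the scatter) for 3-bromophenyl in place of 4-nitrophenyl. Going by these compounds alone, the earlier exchange of nitro for methyl stayed within the scatter, so this is the first change at this ring to give a readable step, and no evidence is at hand to explain it.

The compounds shown leave open whether the bromine itself or its place on the ring matters, as the two change together in both steps. They also leave open how this ring would behave with a chlorine or an amine in the bromine's place.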